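A few compounds are considered here, and "the series" means these few. Any claim that something is new, unique, unknown or untested is made for them only; others in the source may bear on it.

Compound 1, `O=S(=O)(c1ccc(F)c(Cl)c1)c1cnc2c(F)cccc2c1-c1ccccc1F`: 1.39 mL/min
Compound 2, `N#Cc1cccc(S(=O)(=O)c2cnc3cc(F)ccc3c2-c2ccccc2F)c1`: 1.39 mL/min
Compound 3, `N#Cc1cccc(S(=O)(=O)c2cnc3c(F)cccc3c2-c2ccccc2F)c1`: 0.66 mL/min

Of the compounds shown here, three have been measured in an ADME assay on microsomes from liver (Homo sapiens) for metabolic stability, tested at 2.5 uM; on this read-out lower numbers stand for slow clearance and higher numbers for fast clearance. Compound 3 gives 0.66 mL/min, and compound 1, which carries 3-chloro-4-fluorophenyl in place of 3-cyanophenyl on a sulfonyl sulfur, gives 1.39 mL/min; the step of a 2.1-fold higher number from compound 3 to compound 1 (0.32 log units; beyond the scatter). Compound 2 gives 1.39 mL/min, level with compound 1 at the digits reported, and together these two stand highest of the three numbers. Compound 2 and compound 3 are built from the same atoms joined differently; the difference between the two cores is not broken down here, so their two values are simply noted side by side.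

Compound 4, `O=S(=O)(c1ccc(F)c(Cl)c1)c1cnc2cc(F)ccc2c1-c1ccccc1F`, has not yet been measured in this assay. It carries 3-chloro-4-fluorophenyl in place of 3-cyanophenyl on a sulfonyl sulfur, and the place is described in the same words as for the change from compound 3 to compound 1, so the change is the same one, occurring twice among the compounds shown. For the measured compounds named here, the step from compound 2 to compound 4 is expected to be a 1.9-fold higher number from compound 2 to compound 4 (0.27 log units; within the scatter), beside the earlier one, because the only measured instance of this change is a 2.1-fold higher number from compound 3 to compound 1 (0.32 log units; beyond the scatter). With a single prior example on a core that is not the same, the expectation is held loosely. Compound 4 is therefore estimated to give about 2.6 mL/min, within a range from 1.3 mL/min to 5.2 mL/min in this assay.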

Compound 4, intrinsic clearance in a liver preparation (reported as CLH), per the amount of preparation that the assay uses: 1.07 mL/min
Compound 4: the middle estimate sits 2.4-fold (0.39 log units) above what was measured; measured number below the stated range.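

In this assay, 3-chloro-4-fluorophenyl in place of 3-cyanophenyl on the sulfonyl sulfur comes out as a 1.3-fold lower number from compound 2 to compound 4 (0.11 log units; within the scatter), so on this core the two groups are not separated by the measurement. Set against the earlier step, the same change did not carry over from one core to the other at the same size: the same change on two cores in this assay, a 2.1-fold higher number (0.32 log units; beyond the scatter) from compound 3 to compound 1 and a 1.3-fold lower number (0.11 log units; within the scatter) from compound 2 to compound 4, 2.7-fold (0.44 log units) apart, beyond the scatter of two such steps. This shows that, for these two cores, a step measured on one was no safe guide to the step on the other; it does not show what in the cores sets the two steps apart, and with a single pair on each core it says nothing about a third core.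

From the compounds shown here alone, only these two groups are compared on the sulfonyl sulfur, so it stays open whether a group carrying an amine or a carboxylic acid would behave alike on both cores or differ as these two steps do. Going by these compounds, it also stays open how the change would fare on a core with a chlorine or a methoxy group in place of the fluorine of the core.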